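Ethoxycarbonyl to acetyl step in a three-compound series

This account rests on a few compounds, and the source may have more. Where it says the series, first, only, none or still open, it means among the compounds named here.

Measured so far:
compound 1, `C=C(C)[C@@H]1CC=C(Cn2cc(COc3ccc(C4NC(=O)NC(C)=C4C(=O)OCC)cc3)nn2)CC1`, gives 77100 nM in a functional assay on HT-29 cells (Homo sapiens) for inhibition, read by sulforhodamine B assay, with a stated time of 48 h; on this read-out higher numbers stand for weaker inhibition of growth and lower numbers for stronger inhibition of growth
compound 2, `C=C(C)[C@@H]1CC=C(Cn2cc(COc3cccc(C4NC(=O)NC(C)=C4C(=O)OCC)c3)nn2)CC1`, gives 73400 nM in this assay
compound 3, `C=C(C)[C@@H]1CC=C(Cn2cc(COc3ccc(C4NC(=O)NC(C)=C4C(C)=O)cc3)nn2)CC1`, gives 62600 nM in this assay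

All three numbers lie close together, and none of the gaps between them reaches beyond the usual scatter of this kind of measurement, so no order among compound 1, compound 2 and compound 3 can be read from them.

Compound 1 and compound 3 share a core and differ in one place: methyl in place of ethoxy on a carbonyl carbon. That step gave a 1.2-fold lower number from compound 1 to compound 3 (0.09 log units; within the scatter), which is within the scatter.

Compound 2 has the same atoms as compound 1, joined differently; the difference between the two cores is not broken down here. Compound 4, `C=C(C)[C@@H]1CC=C(Cn2cc(COc3cccc(C4NC(=O)NC(C)=C4C(C)=O)c3)nn2)CC1`, is not yet measured and stands to compound 2 as compound 3 stands to compound 1: methyl in place of ethoxy on a carbonyl carbon. The place of the change is described in the same words in both pairs, so this is the same change made on the core of compound 2.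

Going by the values given here, for compound 4 in this assay the expected step is a 1.2-fold lower number from compound 2 to compound 4 (0.07 log units; within the scatter), which rests on the single earlier step from compound 1 to compound 3 being within the scatter, and on compound 2 giving 73400 nM. The estimate for compound 4 is therefore 62000 nM, with a likely range from 30000 nM to 125000 nM. Among the compounds with values here, only one prior instance of the change exists, so the range is kept wide.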

Compound 4, concentration for total growth inhibition: 86200 nM
Compound 4: the middle estimate sits 1.4-fold (0.14 log units) below what was measured, and the stated range covers the measured number.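

In this assay, the ethoxycarbonyl to acetyl change on the core of compound 2 gave a 1.2-fold higher number from compound 2 to compound 4 (0.07 log units; within the scatter), so on this core, as on the core of compound 1, methyl in place of ethoxy on a carbonyl carbon gives a step that stays within the scatter. Set side by side, the two steps do not differ, and the change carries from one core to the other without any distinguishable difference: the same change on two cores in this assay, a 1.2-fold lower number (0.09 log units; within the scatter) from compound 1 to compound 3 and a 1.2-fold higher number (0.07 log units; within the scatter) from compound 2 to compound 4, 1.4-fold (0.16 log units) apart, within the scatter of two such steps. Going by these compounds alone, this shows only that neither core gives a step that can be told apart from the scatter; the opposite directions of the two printed steps cannot be read as a reversal, and two pairs in one cell line do not establish a rule for the series.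

The compounds shown leave open whether a different group on that carbonyl carbon, such as an amine or a hydroxyl, or a longer chain in place of ethoxy, would give a step beyond the scatter. They also leave open whether the ethoxycarbonyl to acetyl change would stay within the scatter on a core carrying a different group in place of the methyl on the shared core.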